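Iodo for Chloro on Two Cores in Macrophage Cytotoxicity

The source may report more compounds than this note shows. Statements on the series, on what has been measured and on what is new or still open speak of the compounds shown alone.

Compound 1 `O=c1oc2ccc(Cl)cc2c(=O)n1-c1ccc(Cl)cc1F` and compound 2 `O=c1oc2ccc(I)cc2c(=O)n1-c1ccc(Cl)cc1F` share one core; compound 3 `O=C(Nc1ccc(F)cc1F)c1cc(Cl)ccc1O` and compound 4 `O=C(Nc1ccc(F)cc1F)c1cc(I)ccc1O` share another, and the difference between the two cores is not broken down here. In an ADME assay on RAW264.7 cells (Mus musculus) for cytotoxicity, read by MTT assay, with a stated time of 24 h (on this read-out higher numbers stand for lower toxicity in this test and lower numbers for higher toxicity in this test), compound 1 gives 6800 nM, compound 2 gives 8900 nM and compound 3 gives 14600 nM. The change from compound 1 to compound 2, (iodo in place of chloro on an aromatic carbon), made the step of a 1.3-fold higher number from compound 1 to compound 2 (0.12 log units; within the scatter). The change from compound 3 to compound 4, (iodo in place of chloro on an aromatic carbon), is the same kind of change, though its ring is not part of a fused or bridged system of two rings, and the place is meta to a large group and para to a hydroxy group rather than meta and para to a fused ring. Because the earlier step of a 1.3-fold higher number from compound 1 to compound 2 (0.12 log units; within the scatter) stayed within the scatter, a step of similar size is expected, a 1.2-fold higher number from compound 3 to compound 4 (0.07 log units; within the scatter). Compound 4 is therefore estimated at 17000 nM, likely between 8000 nM and 36000 nM.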

Compound 4, half-maximal cytotoxic concentration: 13700 nM
Compound 4: middle estimate off by 1.2-fold (0.09 log units), on the high side, within the range that was stated.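

In this assay, iodo in place of chloro gives a 1.1-fold lower number from compound 3 to compound 4 (0.03 log units; within the scatter), and the step on this core agrees with the step on the core of compound 1: the same change on two cores in this assay, a 1.3-fold higher number (0.12 log units; within the scatter) from compound 1 to compound 2 and a 1.1-fold lower number (0.03 log units; within the scatter) from compound 3 to compound 4, 1.4-fold (0.14 log units) apart, within the scatter of two such steps

On these two cores, then, the change carries over as a step that stays within the scatter. This does not show that the two steps truly run in opposite directions, and two cores set no rule for other cores in the series.

The compounds shown carry only chloro or iodo at this place, so it remains open whether an amine or a carboxylic acid there would also stay within the scatter. Going by these compounds, how the same swap would behave at another place on the ring also remains open.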